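Unbound fraction notes: from compound 3 to compound 4

A few compounds are considered here, and "the series" means these few. Any claim that something is new, unique, unknown or untested is made for them only; others in the source may bear on it.

Measured in an ADME assay for protein binding, using equilibrium dialysis, at pH 7.4, tested at 2 uM; a higher number here means a larger unbound share of the compound, a lower number a smaller unbound share:
- compound 1 `CC1CC=C(C(=O)N(c2cc(C#CC(C)(C)C)sc2C(=O)O)C(C)C)CC1`: 0.08
- compound 2 `CC(C)N(c1cc(C#CC(C)(C)C)sc1C(=O)O)C(=O)[C@H]1CC[C@H](C)CC1`: 0.06
- compound 3 `CC(C)N(C(=O)C1CCCCCC1)c1cc(C#CC(C)(C)C)sc1C(=O)O`: 0.11

Compound 3 stands at 0.11, but it holds no separate place among the three. All three values lie within the scatter of each other, so the set shows no order.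

Compound 4 `CC(C)N(C(=O)[C@@H]1CC[C@@H]2C[C@@H]2CC1)c1cc(C#CC(C)(C)C)sc1C(=O)O` is not yet measured. It differs from compound 3 by a group of 8 heavy atoms (8 carbon; one three-membered non-aromatic ring of carbon only, one seven-membered non-aromatic ring of carbon only) in place of a group of 7 heavy atoms (7 carbon; one seven-membered non-aromatic ring of carbon only), on a carbonyl carbon. The entering group has 3 defined stereocentres, 0 hydrogen-bond donors and no net charge.

Three measured steps change the group on this same carbonyl carbon: a 1.3-fold lower number from compound 1 to compound 2 (0.12 log units; within the scatter), a 1.4-fold higher number from compound 1 to compound 3 (0.14 log units; within the scatter) and a 1.8-fold higher number from compound 2 to compound 3 (0.26 log units; within the scatter). Each lies within the scatter. Going by the values given here, none of them brings in a three-membered ring, so they bear on this change only indirectly, and no measured compound carries the entering group.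

On this evidence, no step beyond the scatter is expected in this assay, and the direction is only weakly indicated. The expected step is a 1.2-fold lower number from compound 3 to compound 4 (0.09 log units; within the scatter), which would remain within the scatter. For compound 4 the estimated value is 0.09, with an expected range of 0.05 to 0.15.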

Compound 4, unbound fraction: 0.05
For compound 4 the middle estimate is 1.8-fold (0.26 log units) above the measured one, within the range that was stated.
By their numbers in this assay, from the lowest: compounds 4, 2, 1 and 3 (each within the scatter of the next, the first and the last beyond it).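

In this assay the group on this carbonyl carbon now gives its first step beyond the scatter: a 2.2-fold lower number from compound 3 to compound 4 (0.34 log units; beyond the scatter). This step is modest and appears only against cycloheptyl, as the entering group, which adds a three-membered ring to the seven-membered ring, stays within the scatter of both groups with a six-membered ring: a 1.2-fold lower number from compound 2 to compound 4 (0.08 log units; within the scatter) and a 1.6-fold lower number from compound 1 to compound 4 (0.20 log units; within the scatter). The series therefore separates only at its two ends, compound 3 and compound 4, while compound 1 and compound 2 cannot be placed apart from either of their neighbours in the order, and no measurement on hand accounts for the step.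

The compounds shown do not separate the three-membered ring from the extra carbon it brings, a question that a methyl on the cycloheptyl would address, and they leave open whether the three defined stereocentres of the entering group matter, as no other stereoisomer of it appears here. On these data alone, it also remains open how this assay would respond to a hydroxyl or an amine on the seven-membered ring at this same carbonyl carbon.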